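Chloro for Methoxy on a Series Already at the Limit

A few compounds are considered here, and "the series" means these few. Any claim that something is new, unique, unknown or untested is made for them only; others in the source may bear on it.

Of the compounds shown here, three have so far been tested in a functional assay on HL-60 cells (Homo sapiens) for cytotoxicity, read by MTT assay, with a stated time of 4 days; a lower number here means a stronger inhibitor, a higher number a weaker inhibitor. Compound 1 `C=C1C[C@]23C[C@@]1(O)CC[C@H]2c1ccc(OS(=O)(=O)c2ccc(C)cc2)c(C)c1[C@@H]3Cn1cc(-c2ccc(Cl)cc2)nn1` and compound 2 `C=C1C[C@]23C[C@@]1(O)CC[C@H]2c1ccc(OS(=O)(=O)c2ccc(C)cc2)c(C)c1[C@@H]3Cn1cc(-c2ccc(OC)cc2)nn1` share one core and differ only in a single group on the outer aromatic ring; compound 3 `C=C1C[C@]23C[C@@]1(O)CC[C@@H]2c1cccc(C)c1[C@@H]3Cn1cc(-c2ccc(OC)cc2)nn1` is built on a second core, and the difference between the two cores is not broken down here. In this assay compound 1 gives > 20000 nM, which is a limit of the assay rather than a number. Compound 2 gives > 20000 nM in this assay, again a limit. Compound 3 likewise gives > 20000 nM in this assay, also a limit.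

The change from compound 2 to compound 1 is chloro in place of methoxy on an aromatic carbon. Its step, a step that the two limits leave unreadable from compound 2 to compound 1, cannot be read, since both ends of it sit at the same limit. This is the position shared by everything measured so far: the limit of > 20000 nM in this assay, at which 3 of the 3 values shown sit.

Compound 4 `C=C1C[C@]23C[C@@]1(O)CC[C@@H]2c1cccc(C)c1[C@@H]3Cn1cc(-c2ccc(Cl)cc2)nn1` has not yet been measured. It differs from compound 3 by chloro in place of methoxy on an aromatic carbon, the same change as that from compound 2 to compound 1, now made on the core of compound 3. Among the measured compounds shown here, because the only measured pair carrying this change both sit at the limit of > 20000 nM in this assay, at which 3 of the 3 values shown sit, the step expected is a step that the limit leaves unreadable from compound 3 to compound 4, which amounts to no real movement. Compound 4 is therefore expected to give about 30000 nM in this assay, most likely reported only as a limit, with an estimated span from 12000 nM to 100000 nM.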

Compound 4, half-maximal inhibitory concentration: > 20000 nM
Compound 4 was reported as a limit; the forecaster's own chance of this, stated with the estimate: 85%; the middle value lies beyond the limit too.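

Among the compounds shown here, compound 3 and compound 4 both sit at a limit of the assay rather than at a number, and no step between them can be read, which leaves the effect of chloro in place of methoxy on this core unknown: the limit of > 20000 nM in this assay, at which 4 of the 4 values shown sit.

The compounds shown leave open how these structures rank against one another in this assay, and which change to them would give a measured number instead of a limit.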